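This account rests on a few compounds, and the source may have more. Where it says the series, first, only, none or still open, it means among the compounds named here.

Measured compounds:
compound 1, `CNC(=O)c1cc(Oc2ccc3nc(NC(=O)Nc4cc(C(F)(F)F)cc(C(F)(F)F)c4)sc3c2)ccn1`, giving 88.1%;
compound 2, `CNC(=O)c1cc(Oc2ccc3nc(NC(=O)c4ccc(Cl)cc4Cl)sc3c2)ccn1`, giving 14%.

In a functional assay on SK-BR-3 cells (Homo sapiens) for inhibition, read by MTT assay, with a stated time of 2 days, tested at 10 uM (on this read-out higher numbers stand for more inhibition of growth at the one concentration tested and lower numbers for less inhibition of growth), compound 1 gives 88.1%, while compound 2 gives 14%. Compound 2 thus stands at the lower of the two numbers, and the gap to compound 1 is well beyond the scatter; the two compounds differ in the whole group carried on the shared core, so their values only show that this part of the molecule matters a great deal for the read-out.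

Compound 3, `CNC(=O)c1cc(Oc2ccc3nc(NC(=O)c4ccc(Cl)cc4)sc3c2)ccn1`, is compound 2 with one change: hydrogen in place of chloro on an aromatic carbon. Going by the values given here, no step between two measured compounds describes a change of this kind, so there is no measured guide for its size. Since compound 2 already sits near the bottom of the scale, the room for a further fall is small, and a gain from losing one chloro is not indicated by anything measured. The estimated step is expected to stay within the scatter, with no clear direction; this estimate means a step of a number 2 percentage points lower from compound 2 to compound 3 (within the scatter). Compound 3 is therefore expected to give 12% in this assay, with a range from 0% to 35%.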

Compound 3, percent growth inhibition at one concentration: 18.9%
Beside the measured number, compound 3's estimate is 6.9 percentage points below it; the measured number falls inside the stated range.
By their numbers in this assay, from the lowest: compounds 2 and 3 (each within the scatter of the next); then compound 1.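

Going from 2,4-dichlorophenyl to 4-chlorophenyl in this assay gives a number 4.9 percentage points higher from compound 2 to compound 3 (within the scatter), so this is the first single-place change that can be read in the series. The chloro ortho to a large group and meta to the other chloro can be replaced by hydrogen without a change that can be told from the scatter, so compound 2 and compound 3 stand on the same footing in this read-out. Both values lie low on the scale, which means this reading holds only for compounds with little inhibition of growth, and nothing given explains it.

As far as these compounds go, what a methoxy group, an amine or a carboxylic acid would give at this same place remains open, as does whether this chloro would matter on a compound with a high value such as compound 1. Going by these compounds alone, also open is what the remaining chloro contributes, since replacing it with hydrogen or with a trifluoromethyl group is a separate change that the single step from compound 2 to compound 3 does not address.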